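Nitro-bearing series: aryl ether swap from compound 3

The compounds below may be only part of what the source reports. "The series", "measured", "known", "first", "only" and "open" are said of these compounds alone.

Measured in a functional assay on ileum (Cavia porcellus) for antagonist activity; a lower number here means a stronger inhibitor, a higher number a weaker inhibitor:
- compound 1 `Cc1ccc(CCCCOc2ccc3c(O)c([N+](=O)[O-])c(=O)oc3c2)cc1`: 2500 nM
- compound 2 `CCCc1c(OCCCOc2ccc3c(O)c([N+](=O)[O-])c(=O)oc3c2)ccc(C(C)=O)c1O`: 100 nM
- compound 3 `CCc1ccccc1OCC(O)COc1ccc2c(O)c([N+](=O)[O-])c(=O)oc2c1`: 2700 nM

Compound 3 at 2700 nM is level with compound 1 at 2500 nM, within the scatter. Compound 2 at 100 nM gives a much lower number than compound 3, well beyond the scatter.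

Next in the series is compound 4 `CC(=O)c1ccc(OCC(O)COc2ccc3c(O)c([N+](=O)[O-])c(=O)oc3c2)cc1O`, which has 4-acetyl-3-hydroxyphenyl in place of 2-ethylphenyl on an oxygen on a saturated carbon.

Going by the values given here, no pair of measured compounds differs in one place only, so the data give no direct measure of this change. Among the compounds with values here, the only guide is compound 2 at 100 nM, which also carries acetyl and hydroxyl groups, and it is a loose one. In this assay an estimated step of a 4.5-fold lower number from compound 3 to compound 4 (0.65 log units; beyond the scatter) is expected, towards a stronger inhibitor and beyond the scatter. For compound 4 the expected value is 600 nM, with an estimated range of 150 nM to 2500 nM.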

Compound 4, half-maximal inhibitory concentration: > 20000 nM
Compound 4: only a limit was reported; the forecaster's own chance of this, stated with the estimate: 5%; middle value at least 33-fold (1.52 log units) away from the limit.
By their numbers in this assay, from the lowest: compound 2; then compounds 1 and 3 (each within the scatter of the next). At a limit, above all of these: compound 4.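

In this assay, going by these compounds alone, this is the first change in one place that can be read: 4-acetyl-3-hydroxyphenyl in place of 2-ethylphenyl on an oxygen on a saturated carbon gives an at least 7.4-fold higher number from compound 3 to compound 4 (0.86 log units; beyond the scatter), towards a weaker inhibitor. The group on this oxygen therefore has a clear bearing on the read-out, and on this chain 4-acetyl-3-hydroxyphenyl brings no gain over 2-ethylphenyl. The full size of the step cannot be read, because compound 4 gives only a limit: the limit of > 20000 nM in this assay, at which 1 of the 4 values shown sits.

The compounds shown do not separate the contributions of the acetyl and the hydroxyl, so it stays open which of the two, or whether the pair, goes with the loss. Also open, on these data alone, is how this position would respond to a simple unsubstituted phenyl, or to an aryl group carrying an amine or a carboxylic acid.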